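This account rests on a few compounds, and the source may have more. Where it says the series, first, only, none or still open, it means among the compounds named here.

Series on the core of compound 1 `Cc1[nH]c2ccccc2c1C(c1ccccc1)c1cc2ccccc2o1`. Going by the values given here, in a functional assay on SiHa cells (Homo sapiens) for cytotoxicity (on this read-out higher numbers stand for weaker inhibition and lower numbers for stronger inhibition), compound 1 gives 56500 nM, the only number obtained so far. Compound 2 `O=[N+]([O-])c1ccc2[nH]cc(C(c3ccccc3)c3cc4cc(Cl)ccc4o3)c2c1` reaches only a limit in this assay, > 100000 nM. That limit of compound 2 is the limit of > 100000 nM in this assay, at which 1 of the 2 values shown sits. Compound 3 `COc1ccc2oc(C(c3ccccc3)c3c(C)[nH]c4ccccc34)cc2c1` is the next member, differing from compound 1 by methoxy in place of hydrogen on an aromatic carbon. Among the compounds with values here, no measured pair shows this change, so no step size is known from the data. The expected step is a 1.3-fold lower number from compound 1 to compound 3 (0.10 log units; within the scatter), no larger than the usual scatter. For compound 3 the estimate in this assay is 45000 nM, with a range of 15000 nM to 120000 nM.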

Compound 3, half-maximal inhibitory concentration: > 100000 nM
Compound 3 gave a limit, no number; the forecaster's own chance of this, stated with the estimate: 20%; middle value at least 2.2-fold (0.34 log units) away from the limit.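

In this assay, methoxy in place of hydrogen on an aromatic carbon gives the first step read at this position: an at least 1.7-fold higher number from compound 1 to compound 3 (0.24 log units; that floor lies within the scatter). From the compounds shown here alone, the value of compound 3 is a limit, not a number, so only a floor is known and the true size of the step stays unknown. Most of the series now stands at that limit: the limit of > 100000 nM in this assay, at which 2 of the 3 values shown sit.

Going by these compounds, whether a hydroxyl or an amine on this aromatic carbon would give a number rather than a limit in this assay remains open. Also open, on these data alone, is whether any group here gives a number lower than that of compound 1.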